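A few compounds are considered here, and "the series" means these few. Any claim that something is new, unique, unknown or untested is made for them only; others in the source may bear on it.

Of the compounds shown here, three that share one core have been tested in a functional assay on HCT-116 cells (Homo sapiens) for cytotoxicity, read by MTT assay; on this read-out lower numbers stand for stronger inhibition and higher numbers for weaker inhibition. Compound 1, `Cc1cc(O)c(C(=O)/C=C/c2cccc(Cl)c2)c(=O)o1`, gives 66400 nM. Compound 2, `Cc1cc(O)c(C(=O)/C=C/c2ccc(Cl)cc2Cl)c(=O)o1`, gives 88700 nM. Compound 3, `Cc1cc(O)c(C(=O)/C=C/c2ccc(Cl)c(Cl)c2)c(=O)o1`, gives only a limit, > 100000 nM, which is the upper limit of the assay, (the limit of > 100000 nM in this assay, at which 1 of the 3 values shown sits). Compound 1 and compound 2 sit within the usual scatter of each other, so their two numbers are read as alike. Compound 2 and compound 3 are built from the same atoms joined differently, and the difference between their two cores is not broken down here.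

One change has been measured: going from compound 3 to compound 1, the structures differ by hydrogen in place of chloro on an aromatic carbon, and the step in this assay is an at least 1.5-fold lower number from compound 3 to compound 1 (0.17 log units; that floor lies within the scatter).

The unmeasured compound 4, `Cc1cc(O)c(C(=O)/C=C/c2ccccc2Cl)c(=O)o1`, arises from compound 2 by the same kind of change, (hydrogen in place of chloro on an aromatic carbon). The surroundings differ: in the measured step the carbon that loses its chloro is ortho to a chloro group, while in compound 2 it is meta to a chloro group.

Resting on the measured step from compound 3 to compound 1, an at least 1.5-fold lower number from compound 3 to compound 1 (0.17 log units; that floor lies within the scatter), a step of similar size toward a lower number is expected from compound 2 to compound 4, about a 1.5-fold lower number from compound 2 to compound 4 (0.17 log units; within the scatter). Compound 4 is therefore estimated at 60000 nM, expected to fall between 30000 nM and 120000 nM.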

Compound 4, half-maximal inhibitory concentration: > 100000 nM
Compound 4 was reported as a limit (the forecaster's own chance of this, stated with the estimate: 20%); middle value at least 1.6-fold (0.22 log units) away from the limit.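

Compound 4 gives only a limit in this assay, > 100000 nM, and not a number. With hydrogen in place of chloro on compound 2, the result can therefore be read only as a floor, an at least 1.1-fold higher number from compound 2 to compound 4 (0.05 log units; that floor lies within the scatter), so no clear change is shown. The two floors point in opposite directions, but neither step has a fixed size, so this does not show that the change acts differently on the two cores, nor that it carries over from one to the other with the same size: the same change on two cores in this assay, an at least 1.5-fold lower number (0.17 log units; that floor lies within the scatter) from compound 3 to compound 1 and an at least 1.1-fold higher number (0.05 log units; that floor lies within the scatter) from compound 2 to compound 4; the limit leaves it open whether they differ.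

The aromatic rings shown carry only chloro groups, so it remains open whether a methoxy group, an amine or a carboxylic acid in place of chloro would give a number clearly lower than those seen so far, or whether a ring with no chloro at all would behave like these compounds. Going by these compounds, it also remains open how large the steps to compound 3 and compound 4 really are, since their values give no exact number to compare: the limit of > 100000 nM in this assay, at which 2 of the 4 values shown sit.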